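The source may report more compounds than this note shows. Statements on the series, on what has been measured and on what is new or still open speak of the compounds shown alone.

Measured compounds:
- compound 1, `Cc1nc(N)c2nn(Cc3ccccc3)cc2n1`: 1%
- compound 2, `Cn1cc2nc(CCCc3ccccc3)nc(N)c2n1`: 36%

Both numbers come from an assay on CHO cells for displacement of a labelled ligand from adenosine receptor A1 (Homo sapiens), read by scintillation counting, with a stated time of 120 min, tested at 1 uM; on this read-out higher numbers stand for more inhibition at the one concentration tested (going by the name of the read-out) and lower numbers for less inhibition. Compound 1 gives 1% in this assay, the lower of the two numbers shown. Compound 2 gives 36% in this assay, a number that lies beyond the usual scatter above that of compound 1; the two compounds differ in more than one place, so no single structural step can be read off between them.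

The step followed here leads from compound 1 to compound 3, `Nc1nc(Cc2ccccc2)nc2cn(Cc3ccccc3)nc12`, which has not yet been measured in this assay. The change is phenyl in place of hydrogen on a saturated chain carbon bound to an aromatic carbon. Among the compounds with values here, compound 2, the only other compound measured, also carries a phenyl ring at the end of a chain on the shared core and shows the higher number, so a rise in inhibition from compound 1 to compound 3 is expected rather than a fall, though its size is uncertain with only two compounds to lean on. The expected step is a number 19 percentage points higher from compound 1 to compound 3 (beyond the scatter). Compound 3 is therefore estimated to give 20% in this assay, within a range from 2% to 50%.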

Compound 3, a percentage reported as inhibition, at one concentration (the size of the read-out at that concentration, not a potency): 1%
Estimate against measurement, compound 3: 19 percentage points above; the whole stated range lies above it.
By their numbers in this assay, from the lowest: compounds 1 and 3 (each within the scatter of the next); then compound 2.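

In this assay, putting phenyl in place of hydrogen on a saturated chain carbon bound to an aromatic carbon, which amounts to methyl becoming benzyl, gives no change at the digits printed from compound 1 to compound 3 (within the scatter) at the one concentration tested. Within the data shown here, this shows that adding this ring at this place is not enough on its own to raise the inhibition of the core of compound 1, something the earlier compounds could not show because they differ in more than one place. Nothing available here explains why the number stays put.

Going by these compounds, compound 2 differs from compound 1 and from compound 3 in more than one place, so which of those differences goes with compound 2 giving 36% in this assay remains unknown. On these data alone, it also remains open whether a longer chain carrying the phenyl ring, or an amine or a carboxylic acid at this same place, would move the number at all.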